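Working notes: the step from compound 3 to compound 4

The source may hold more compounds than are shown below. What is called first, only, known or untested is meant among the compounds shown, and "the series" means these compounds.

Measured so far in a functional assay on HepG2 cells (Homo sapiens) for antiproliferative activity, read by MTT assay, with a stated time of 24 h; a lower number here means a stronger inhibitor, a higher number a weaker inhibitor:
- compound 1 `C=CCOc1ccc2c(=O)c(-c3cc(OC)c(OC)cc3OC)coc2c1` gives 3450 nM
- compound 2 `COc1cccc(C(=O)Oc2ccc3c(=O)c(-c4cc(OC)c(OC)cc4OC)coc3c2)c1` gives > 10000 nM as a limit of the assay, not a number
- compound 3 `COc1cc(OC)c(-c2coc3cc(OCc4ccc(Cl)cc4)ccc3c2=O)cc1OC` gives 940 nM

Among the measured compounds shown here, compound 3 at 940 nM holds the lower of the two actual numbers, and the only other number belongs to compound 1. The value of compound 2 is only a limit.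

Compound 4 `COc1cc(OC)c(-c2coc3cc(OCc4ccccc4Br)ccc3c2=O)cc1OC` carries 2-bromophenyl in place of 4-chlorophenyl on a saturated chain carbon bound to an oxygen on an aromatic ring.

Three measured steps change the group on that same oxygen. The number rises in an at least 2.8-fold higher number from compound 1 to compound 2 (0.46 log units; beyond the scatter) and falls modestly in a 3.7-fold lower number from compound 1 to compound 3 (0.56 log units; beyond the scatter), while an at least 10-fold lower number from compound 2 to compound 3 (1.02 log units; beyond the scatter) is large. These steps show that this assay responds to this group, but none of them varies the halogen. Compound 4 differs from compound 3 only as 4-chlorobenzyl to 2-bromobenzyl, so a step well short of the large one is expected, probably none beyond the scatter. For the measured compounds named here, a slight lean towards a higher number is expected, as compound 3 has the lowest number so far.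

The expected change for compound 4 is a 1.5-fold higher number from compound 3 to compound 4 (0.17 log units; within the scatter) in this assay overall. Compound 4 is estimated at 1400 nM with an expected range from 450 nM to 4500 nM overall.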

Compound 4, half-maximal inhibitory concentration: 2180 nM
Compound 4: middle estimate off by 1.6-fold (0.19 log units), on the low side, and the stated range covers the measured number.
By their numbers in this assay, from the lowest: compound 3; then compounds 4 and 1 (each within the scatter of the next). At a limit, above all of these: compound 2.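

In this assay, among the compounds shown here, a 2.3-fold higher number from compound 3 to compound 4 (0.37 log units; beyond the scatter), so the number responds to a change within the halogen-bearing benzyl group alone, whereas the earlier steps replaced the whole group on the oxygen. Against the allyl group, a 1.6-fold lower number from compound 1 to compound 4 (0.20 log units; within the scatter), so 2-bromobenzyl does not separate from allyl in this assay, and a benzyl group on this oxygen does not by itself give the lower number seen with 4-chlorobenzyl in compound 3. The value of compound 2 is a limit and not a number, and an at least 4.5-fold lower number from compound 2 to compound 4 (0.66 log units; beyond the scatter) can be read only as a bound: the limit of > 10000 nM in this assay, at which 1 of the 4 values shown sits.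

The halogen and its place on the ring change together between 4-chlorobenzyl and 2-bromobenzyl, so the compounds shown do not tell which of the two carries the step; 2-chlorobenzyl and 4-bromobenzyl would separate them, and plain benzyl would show what either halogen adds. Also open is how this position reads with an amine or a carboxylic acid at the end of a longer chain on the oxygen, as every group shown here is either an allyl, a benzyl or an aroyl group.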